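The source may hold more compounds than are shown below. What is called first, only, known or untested is meant among the compounds shown, and "the series" means these compounds.

Measured in a functional assay on OVCAR-5 cells (Homo sapiens) for cytotoxicity, read by sulforhodamine B assay, with a stated time of 48 h, tested at 0.1 uM; a lower number here means a stronger effect, a higher number a weaker effect of the compound at the concentration tested:
compound 1, `COc1cc(-c2cc(/C=C/C(=O)c3ccc(Cl)c(Cl)c3)[nH]n2)cc(OC)c1OC`: 99%
compound 2, `COc1ccc(-c2cc(/C=C/C(=O)c3ccc(N)cc3)[nH]n2)cc1OC`: 95%
compound 3, `COc1ccc(-c2cc(/C=C/C(=O)c3ccc(N)cc3)[nH]n2)cc1`: 95%

In this assay compound 1 stands within the usual scatter of compounds 2 and 3; all three leave the cells close to fully viable at this concentration. Compound 4, `COc1cc(-c2cc(/C=C/C(=O)c3ccc(F)c(F)c3)[nH]n2)cc(OC)c1OC`, differs from compound 1 by 3,4-difluorophenyl in place of 3,4-dichlorophenyl on a carbonyl carbon. Among the compounds with values here, the only measured step, no change at the digits printed from compound 2 to compound 3 (within the scatter), concerns a methoxy group on a different part of the molecule and does not touch the 3,4-dichlorophenyl, so it gives no direct guide to putting 3,4-difluorophenyl in its place. Since every measured compound sits near the top of the scale in this assay, compound 4 is expected to stay there too, with a step of a number 2 percentage points lower from compound 1 to compound 4 (within the scatter), nothing beyond the scatter. The estimate for compound 4 is 97%, in the range 85% to 105%.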

Compound 4, a percentage reported as activity, at one concentration (the size of the read-out at that concentration, not a potency): 93%
Estimate against measurement, compound 4: 4 percentage points above; measured number inside the range.
By their numbers in this assay, from the lowest: compounds 4, 2, 3 and 1 (each within the scatter of the next).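

Until now, nothing showed what a change to the 3,4-dichlorophenyl on the carbonyl carbon would do. In this assay, putting 3,4-difluorophenyl in its place gives a number 6 percentage points lower from compound 1 to compound 4 (within the scatter), so these two groups cannot be told apart at this concentration. No measurement shown here offers an explanation for this result.

Going by these compounds, because the compounds sit near the top of the scale, it remains open whether these two groups would differ at higher concentrations. On these data alone, it is also open whether a nitrile or a carboxylic acid in place of the halogens would give a clearly different number.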